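This account rests on a few compounds, and the source may have more. Where it says the series, first, only, none or still open, it means among the compounds named here.

Working notes on the series.

Compound 1 `O=C1C2CCCCN2C(=O)N1CCCN1CCN(c2cccc(C(F)(F)F)c2)CC1` and compound 3 `O=C1C2CCCN2C(=O)N1CCCCN1CCN(c2cccc(C(F)(F)F)c2)CC1` are built from the same atoms joined differently; the difference between the two cores is not broken down here. Compound 2 `O=C1C2CCCCN2C(=O)N1CCCN1CCN(c2ccc([N+](=O)[O-])cc2)CC1` derives from compound 1 by the change (4-nitrophenyl in place of 3-(trifluoromethyl)phenyl on an amine nitrogen in a ring). Compound 4 `O=C1C2CCCN2C(=O)N1CCCCN1CCN(c2ccc([N+](=O)[O-])cc2)CC1` derives from compound 3 by 4-nitrophenyl in place of 3-(trifluoromethyl)phenyl on an amine nitrogen in a ring, the same change at a place described in identical words, so the two cases are treated as the same change.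

In an assay on isolated protein for binding affinity to Adrenergic receptor alpha-1 (Rattus norvegicus), read by radioligand binding (on this read-out higher numbers stand for weaker inhibition and lower numbers for stronger inhibition), compound 1 gives 90.4 nM. Compound 3 gives 64.9 nM in this assay, which lies within the scatter of compound 1, so no order between the two is drawn. For compound 2 this assay reports only a limit, > 1000 nM, and not a number. As far as these compounds go, the change from compound 1 to compound 2 thus appears as an at least 11-fold higher number from compound 1 to compound 2 (1.04 log units; beyond the scatter), and its true size stays unknown because the limit of > 1000 nM in this assay, at which 1 of the 3 values shown sits, caps what can be seen.

For the same change made on the core of compound 3, a step of comparable floor is expected, a 15-fold higher number from compound 3 to compound 4 (1.19 log units; beyond the scatter), resting on the measured step of an at least 11-fold higher number from compound 1 to compound 2 (1.04 log units; beyond the scatter). Compound 4 is therefore estimated at 1000 nM, with an expected range from 450 nM to 3000 nM, and a real chance that this assay again returns only a limit rather than a number.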

Compound 4, inhibition constant: 247 nM
Estimate against measurement, compound 4: 4.0-fold (0.61 log units) above; the whole stated range lies above it.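

In this assay the replacement of 3-(trifluoromethyl)phenyl by 4-nitrophenyl on an amine nitrogen in a ring gives a 3.8-fold higher number from compound 3 to compound 4 (0.58 log units; beyond the scatter), so the direction of the change carries over from the core of compound 1 to the second core. The size of the change does not carry over unchanged: the same change on two cores in this assay, an at least 11-fold higher number (1.04 log units; beyond the scatter) from compound 1 to compound 2 and a 3.8-fold higher number (0.58 log units; beyond the scatter) from compound 3 to compound 4, at least 2.9-fold (0.46 log units) apart, beyond the scatter of two such steps Compound 2 gives only a limit and not a number, so the step on the core of compound 1 has no known true size, the gap between the two steps has only a floor, and one pair of cores sets no rule for any further core: the limit of > 1000 nM in this assay, at which 1 of the 4 values shown sits.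

Which part of the two cores goes with the difference between the steps stays open, since the core of compound 1 and the core of compound 3 are compared here only as wholes. Also open, as far as these compounds go, is how the step would read with a phenyl group carrying a nitrile or an amine in place of 3-(trifluoromethyl)phenyl on the same nitrogen, or with a longer chain between that ring and the core.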